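The compounds below may be only part of what the source reports. "The series", "measured", "known", "first", "only" and "open" are said of these compounds alone.

Working notes on the series. The shared core of compound 1 `CC(C)n1ncc2c(C(=O)Nc3ccccc3)cccc21` carries an amide whose nitrogen bears a phenyl group; in a functional assay on MCF7 cells (Homo sapiens) for inhibition, read by MTT assay, with a stated time of 72 h (on this read-out higher numbers stand for weaker inhibition and lower numbers for stronger inhibition), compound 1 gives 19700 nM. Compound 2 `CC(C)n1ncc2c(C(=O)NC3CCCC3)cccc21` puts cyclopentyl in place of phenyl on that amide-type nitrogen. In this assay compound 2 reaches only a limit of the assay, > 40000 nM. Among the compounds with values here, the single measured step is an at least 2.0-fold higher number from compound 1 to compound 2 (0.30 log units; that floor lies within the scatter). Compound 3 `CC(C)n1ncc2c(C(=O)NCc3cn(-c4cccc(F)c4)nn3)cccc21` extends the amide through a methylene to a five-membered aromatic ring with 3 nitrogen that bears 3-fluorophenyl. In this assay compound 3 likewise gives only a limit, > 40000 nM. Compound 3 therefore stands at the limit of > 40000 nM in this assay, at which 2 of the 3 values shown sit, with no number of its own.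

Compound 4 `COc1ccc(Cn2cc(CNC(=O)c3cccc4c3cnn4C(C)C)nn2)cc1` differs from compound 3 by 4-methoxybenzyl in place of 3-fluorophenyl on an aromatic nitrogen. Within the data shown here, no measured step touches this aromatic nitrogen; the one step known, from an amide-type nitrogen, did not move the read-out beyond the limit and so gives no direction for this change. The expectation for this assay is therefore no step beyond the scatter, with compound 4 most likely again at the limit; the step expected is a step that the limit leaves unreadable from compound 3 to compound 4. For compound 4 the estimate in this assay is 45000 nM, within 15000 nM to 150000 nM.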

Compound 4, half-maximal inhibitory concentration: > 40000 nM
Compound 4: no number, only a limit (the forecaster's own chance of this, stated with the estimate: 75%); the middle value does not contradict the limit.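

In this assay compound 4 gives only a limit, > 40000 nM. Compound 3 also stands at a limit, so no step can be read between compound 3 and compound 4. The series now stands as follows: the limit of > 40000 nM in this assay, at which 3 of the 4 values shown sit. The compounds shown leave open how 4-methoxybenzyl and 3-fluorophenyl on that aromatic nitrogen compare in this assay.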